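A few compounds are considered here, and "the series" means these few. Any claim that something is new, unique, unknown or untested is made for them only; others in the source may bear on it.

Compound 1 `COCOc1cc(/C=C/C(=O)OCC(=O)NCc2ccco2)ccc1OCc1ccccc1` is the starting point of this step. In a functional assay on LS174T cells (Homo sapiens) for cytotoxicity, read by MTT assay, with a stated time of 72 h (a lower number here means a stronger inhibitor, a higher number a weaker inhibitor), compound 1 reaches only a limit of the assay, > 200000 nM, so no number is known for it and it cannot be placed against the other values. Compound 2 `COc1ccc(NC(=O)COC(=O)/C=C/c2cc(OC)c(OCc3ccc(Cl)c(Cl)c3)c(OC)c2)cc1` likewise gives only a limit in this assay, > 200000 nM. Within the data shown here, compound 3 `O=C(/C=C/c1ccccc1)NNC(=O)c1ccccc1O` is the one compound with a number: in this assay compound 3 gives 20100 nM. The step to compound 4 `COCOc1cc(/C=C/C(=O)OCC(=O)Nc2ccc(OC)cc2)ccc1OCc1ccccc1` is a single exchange on the core of compound 1: 4-methoxyphenyl in place of (furan-2-yl)methyl on an amide-type nitrogen. Among the measured compounds shown here, no measured pair shows this exchange, so its size in this assay cannot be read from data, and the only evidence is the limit of > 200000 nM in this assay, at which 2 of the 3 values shown sit. Compound 4 is expected to stay at the limit as well, a step that the limit leaves unreadable from compound 1 to compound 4 that is expected to lie within the usual scatter. The estimate for compound 4 is 250000 nM, in a range from 100000 nM to 600000 nM, with a limit rather than a number the more likely report.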

Compound 4, half-maximal inhibitory concentration: > 200000 nM
Compound 4: no number, only a limit; the forecaster's own chance of this, stated with the estimate: 85%; the middle value is on the limit's open side.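

In this assay, among these compounds, compound 4 gives only a limit, > 200000 nM; compound 1 also gives only a limit, so no step between compound 1 and compound 4 can be read. The compounds shown leave open whether any group on that amide-type nitrogen brings the shared core to a measurable value.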